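Swapping the phenyl sulfonyl for a pyridyl sulfonyl

The compounds below may be only part of what the source reports. "The series", "measured", "known", "first", "only" and "open" are said of these compounds alone.

Compound 1 `Cc1ccc2[nH]c(C(=O)N[C@H]3CN(S(=O)(=O)c4ccccc4)C[C@@H]3C(=O)NCCN(C)C)cc2c1` gives 16 uL/min in an ADME assay on cells (Hepatocyte, Rattus norvegicus) for metabolic stability; a higher number here means faster removal of the compound, a lower number slower removal.
Compound 2 `Cc1ccc2[nH]c(C(=O)N[C@H]3CN(S(=O)(=O)c4ccnnc4)C[C@@H]3C(=O)NCCN(C)C)cc2c1` gives 2 uL/min in this assay.
Compound 3 `Cc1ccc2[nH]c(C(=O)N[C@H]3CCN(S(=O)(=O)c4ccccc4)C[C@@H]3C(=O)NCCN(C)C)cc2c1` gives 16 uL/min in this assay.

Compound 3 stands level with compound 1 at the digits shown, and the two together hold the highest numbers of the three; compound 2 sits well under both, an 8.0-fold lower number from compound 1 to compound 2 (0.90 log units; beyond the scatter) being the only step beyond the scatter in this set. Compound 4 `Cc1ccc2[nH]c(C(=O)N[C@H]3CCN(S(=O)(=O)c4cccnc4)C[C@@H]3C(=O)NCCN(C)C)cc2c1` differs from compound 3 in one place: pyridin-3-yl in place of phenyl on a sulfonyl sulfur. Among the compounds with values here, the step that bears on this is the one from compound 1 to compound 2, where pyridazin-4-yl replaced phenyl on the same sulfonyl sulfur, on the core before its ring was enlarged, and the number fell by an 8.0-fold lower number from compound 1 to compound 2 (0.90 log units; beyond the scatter). The change here puts in pyridin-3-yl rather than pyridazin-4-yl, so the measured step is a guide but not an exact match. Compound 4 is therefore expected to sit below compound 3 in this assay, by a step of about a 2.7-fold lower number from compound 3 to compound 4 (0.43 log units; beyond the scatter). Compound 4 is estimated at 6 uL/min. For compound 4 the likely range runs from 2.5 uL/min to 14 uL/min.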

Compound 4, intrinsic clearance in a liver preparation (reported as CLH), per the amount of preparation that the assay uses: 5 uL/min
Estimate against measurement, compound 4: 1.2-fold (0.08 log units) above; the range from low to high includes it.
By their numbers in this assay, from the lowest: compound 2; then compound 4; then compounds 1 and 3 (each within the scatter of the next).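

The step to pyridin-3-yl on a sulfonyl sulfur, a 3.2-fold lower number from compound 3 to compound 4 (0.51 log units; beyond the scatter) in this assay, shows that the lower number seen earlier with pyridazin-4-yl is not tied to that one group or to the core of compound 1. Among the compounds shown, both changes that replace phenyl on this sulfur with a ring containing nitrogen lower the number beyond the scatter, and no compound here goes against that, although the pattern rests on only two pairs. Nothing shown gives a measured reason for the drop in either pair, so the data record the change in the number but not its cause.

The two steps differ in both the incoming group and the core, so the compounds shown cannot separate the effect of the ring from that of the core; pyridin-3-yl on the core of compound 1 and pyridazin-4-yl on the core of compound 3 would be the direct tests. As far as these compounds go, it also remains open how pyridin-2-yl, pyridin-4-yl or pyrimidin-5-yl on the same sulfur would read in this assay, and so whether the place and number of ring nitrogens matter.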